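Changing the aryl on the triazole nitrogen of the shared core

This account rests on a few compounds, and the source may have more. Where it says the series, first, only, none or still open, it means among the compounds named here.

Three compounds share one core and differ only in the aryl group on an aromatic nitrogen. Compound 1 `CCc1ccccc1-n1nncc1CN1C(=O)C2(C(C#N)=C(N)Oc3c(N)cc4nc5ccccc5nc4c32)c2ccccc21` carries 2-ethylphenyl there, and in a functional assay on HepG2 cells (Homo sapiens) for antiproliferative activity, read by MTT assay, with a stated time of 48 h (a higher number here means a weaker inhibitor, a lower number a stronger inhibitor), compound 1 gives 17900 nM. Compound 2 `CC(=O)Nc1ccc(-n2nncc2CN2C(=O)C3(C(C#N)=C(N)Oc4c(N)cc5nc6ccccc6nc5c43)c3ccccc32)cc1` carries 4-acetamidophenyl. In this assay compound 2 gives > 50000 nM, which is a limit of the assay and not a number (the limit of > 50000 nM in this assay, at which 1 of the 3 values shown sits). Compound 3 `Cc1ccc(Cl)cc1-n1nncc1CN1C(=O)C2(C(C#N)=C(N)Oc3c(N)cc4nc5ccccc5nc4c32)c2ccccc21` carries 5-chloro-2-methylphenyl, and in this assay compound 3 gives 17300 nM, a number that sits within the scatter of compound 1, as a 1.0-fold lower number from compound 1 to compound 3 (0.01 log units; within the scatter) shows. The other two steps, an at least 2.7-fold higher number from compound 1 to compound 2 (0.44 log units; beyond the scatter) and an at least 2.8-fold lower number from compound 2 to compound 3 (0.46 log units; beyond the scatter), are the only ones beyond the scatter, and both turn on the 4-acetamidophenyl group.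

Compound 4 `COc1cc(-n2nncc2CN2C(=O)C3(C(C#N)=C(N)Oc4c(N)cc5nc6ccccc6nc5c43)c3ccccc32)c(OC)cc1Cl` differs from compound 3 in this way: 4-chloro-2,5-dimethoxyphenyl in place of 5-chloro-2-methylphenyl on an aromatic nitrogen. The entering group keeps a chlorine but, like the group in compound 2, brings hydrogen-bond acceptors to the aryl, and the step of an at least 2.8-fold lower number from compound 2 to compound 3 (0.46 log units; beyond the scatter) ran against such a group. One therefore expects a modest weakening, a 1.5-fold higher number from compound 3 to compound 4 (0.18 log units; within the scatter). Compound 4 is estimated at 26000 nM, within a range from 12000 nM to 50000 nM.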

Compound 4, half-maximal inhibitory concentration: > 50000 nM
Compound 4 ended at the assay's limit (the forecaster's own chance of this, stated with the estimate: 25%); middle value at least 1.9-fold (0.28 log units) from the limit.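

Keeping a chlorine on the aryl does not hold the level of compound 3: the change gives an at least 2.8-fold higher number from compound 3 to compound 4 (0.46 log units; beyond the scatter), and the change from 2-ethylphenyl gives an at least 2.7-fold higher number from compound 1 to compound 4 (0.44 log units; beyond the scatter). Compound 4, like compound 2, ends at a limit of this assay and not at a number: the limit of > 50000 nM in this assay, at which 2 of the 4 values shown sit.

Among these four compounds, the two aryl groups that carry oxygen, in compound 2 and compound 4, sit at the limit, while the two without oxygen, in compound 1 and compound 3, give numbers; the step between compound 2 and compound 4 cannot be read.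

The compounds shown leave open whether the loss goes with one methoxy group or needs both. They also leave open what a single methoxy, an amine or a carboxylic acid on the aryl would give.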